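This account rests on a few compounds, and the source may have more. Where it says the series, first, only, none or still open, it means among the compounds named here.

Values so far in a physicochemical assay for solubility, measured as kinetic solubility; a lower number here means a less soluble compound, a higher number a more soluble compound:
- compound 1 `CC(=O)Nc1cc(-c2ccc(N(C)C(=O)c3c(F)cccc3Cl)c(N3CC4CC4C3)c2)n(C2CCCC2)n1`: 0.1 ug/mL
- compound 2 `CC(=O)Nc1cc(-c2cnc(N(C)C(=O)c3c(F)cccc3Cl)c(N3CCCCC3)c2)n(C(C)C)n1`: 37.4 ug/mL
- compound 3 `CC(C)n1nc(C(N)=O)cc1-c1ccc(N(C)C(=O)c2c(F)cccc2Cl)c(OCC(F)(F)F)c1`: 32 ug/mL

Compound 1 stands lowest of the three, and its gaps to compound 3 and to compound 2 both lie beyond the scatter. Going by the values given here, no two measured compounds differ in one place only, so the series offers no direct step to lean on.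

The next compound to be read is compound 4 `CC(=O)Nc1cc(-c2ccc(N(C)C(=O)c3c(F)cccc3Cl)c(N3CC4CC4C3)c2)n(CC(C)(C)C)n1`, which has neopentyl in place of cyclopentyl on an aromatic nitrogen and otherwise matches compound 1. Among the compounds with values here, the expectation rests mainly on compound 1 at 0.1 ug/mL as the only close neighbour, and it remains weakly supported. In this assay a small upward step, about the size of the scatter, is expected. The estimated change is a 2.0-fold higher number from compound 1 to compound 4 (0.30 log units; within the scatter). Such a change should stay far short of the gaps that separate compound 1 from compound 2 and compound 3. The estimate for compound 4 is 0.2 ug/mL (expected range 0.05 ug/mL to 1 ug/mL) for this reading.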

Compound 4, solubility: 0.8 ug/mL
Compound 4: the middle estimate sits 4.0-fold (0.60 log units) below what was measured; the measured number falls inside the stated range.
By their numbers in this assay, from the lowest: compound 1; then compound 4; then compounds 3 and 2 (each within the scatter of the next).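

In this assay, going by these compounds alone, neopentyl in place of cyclopentyl on the aromatic nitrogen gives an 8.0-fold higher number from compound 1 to compound 4 (0.90 log units; beyond the scatter), the first step that changes one place only. The two groups have the same heavy-atom count and neither carries a hydrogen-bond donor, acceptor or net charge, so the counted difference is the loss of the ring, and this position is not indifferent to that exchange. Nothing measured on these compounds accounts for the step.

Open, from the compounds shown here alone, is whether a chain carrying an amine or a carboxylic acid on this nitrogen would shift this assay further than neopentyl does. Also open, going by these compounds, is whether the step holds on other cores, since the isopropyl compounds differ from compound 4 in more than one place.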